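Cytotoxicity of triazole-thione hydrazones: from fluoro to phenyl

The compounds below may be only part of what the source reports. "The series", "measured", "known", "first", "only" and "open" are said of these compounds alone.

Measured so far:
- compound 1, `CS(=O)(=O)c1ccc(Cc2n[nH]c(=S)n2/N=C/c2ccc(Cl)cc2)cc1`: 57%
- compound 2, `CS(=O)(=O)c1ccc(Cc2n[nH]c(=S)n2/N=C/c2ccc(F)cc2)cc1`: 57.8%

In a functional assay on HeLa cells (Homo sapiens) for cytotoxicity, read by MTT assay, with a stated time of 48 h, tested at 100 uM (a lower number here means a weaker effect, a higher number a stronger effect of the compound at the concentration tested), compound 1 gives 57%. Compound 2 differs from it by fluoro in place of chloro on an aromatic carbon, and in this assay compound 2 gives 57.8%. Among the compounds with values here, the step of a number 0.8 percentage points higher from compound 1 to compound 2 (within the scatter) lies within the scatter, so the two halogen analogues cannot be told apart on these numbers; compound 2 is nominally the higher of the two, with compound 1 as its only neighbour.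

Compound 3, `CS(=O)(=O)c1ccc(Cc2n[nH]c(=S)n2/N=C/c2ccc(-c3ccccc3)cc2)cc1`, has not been measured in this assay. The change from compound 2 is phenyl in place of fluoro on an aromatic carbon. Within the data shown here, no measured step involves a phenyl entering at this position; the only step available, a number 0.8 percentage points higher from compound 1 to compound 2 (within the scatter), concerns a swap between two halogens and was within the scatter. The data therefore give no direct guide to the size or direction of the coming step, and a step no larger than the scatter is the plainest expectation.

Compound 3 is therefore estimated at 58%, within 40% to 78%. That estimate corresponds to an expected step of a number 0.2 percentage points higher from compound 2 to compound 3 (within the scatter).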

Compound 3, a percentage reported as activity, at one concentration (the size of the read-out at that concentration, not a potency): 69.5%
For compound 3 the middle estimate is 11.5 percentage points below the measured one; measured number inside the range.
By their numbers in this assay, from the lowest: compounds 1 and 2 (each within the scatter of the next); then compound 3.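

Within the data shown here, at the position para to a large group, the two halogens had given no readable difference, so the earlier compounds did not show whether the substituent here matters at all in this assay at the concentration tested. Phenyl settles that: with its 6 heavy atoms and one six-membered aromatic ring in place of a single halogen atom, it gives a number 11.7 percentage points higher from compound 2 to compound 3 (beyond the scatter) and, measured against the chloro analogue, a number 12.5 percentage points higher from compound 1 to compound 3 (beyond the scatter) in the same direction, so the outcome does not depend on which halogen leaves. No supporting measurement bears on why the number rises, and the data cannot say which feature of the phenyl group is responsible.

The compounds shown leave open whether an aromatic ring is needed at this position or whether a cyclohexyl ring, a longer alkyl chain or a methoxy group would do the same, and whether an amine or a carboxylic acid on the added phenyl ring would keep the gain. Going by these compounds, each compound also has a single reading at one concentration, so whether the stronger effect of compound 3 at that concentration would hold at other concentrations remains unknown.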